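Adding a Third Methoxy Group to the Benzyl Side Chain

The compounds below may be only part of what the source reports. "The series", "measured", "known", "first", "only" and "open" are said of these compounds alone.

Measured so far:
Compound 1, `Nc1cc(N)c2nc(-c3ccccc3)c(NCc3ccc(Cl)c(Cl)c3)nc2c1`, gives 89100 nM in a functional assay on SF-295 cells (Homo sapiens) for inhibition, read by sulforhodamine B assay, with a stated time of 48 h; a lower number here means that less compound is tolerated, a higher number that more compound is tolerated.
Compound 2, `COc1ccc(CNc2nc3cc(N)cc(N)c3nc2-c2ccccc2)cc1OC`, gives 58900 nM in this assay.
Compound 3, `CCOC(=O)[C@H](CCC(=O)O)NC(=O)c1ccc(Sc2nc3cc(N)cc(N)c3nc2-c2ccccc2)cc1`, gives only a limit of the assay, < 100000 nM, in this assay.

All three share the same core and differ only in the group hanging from it. Compound 2 and compound 1 are within the scatter of each other, so neither can be called the more tolerated one; compound 3 contributes only a limit, shown as the limit of < 100000 nM in this assay, at which 1 of the 3 values shown sits, and no number. Among the measured compounds shown here, the single measured change, a 1.5-fold lower number from compound 1 to compound 2 (0.18 log units; within the scatter), put 3,4-dimethoxyphenyl in place of 3,4-dichlorophenyl on a saturated chain carbon bound to a nitrogen on an aromatic ring, and this swap of two quite different substituents moved the read-out hardly at all.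

Compound 4, `COc1cc(CNc2nc3cc(N)cc(N)c3nc2-c2ccccc2)cc(OC)c1OC`, takes the next step: methoxy in place of hydrogen on an aromatic carbon, ortho to a methoxy group and meta to a large group and to a methoxy group. For the measured compounds named here, this is a smaller change than the one made from compound 1 to compound 2, which itself stayed within the scatter, so no step beyond the scatter is expected in this assay: a 1.1-fold lower number from compound 2 to compound 4 (0.03 log units; within the scatter) is the expected outcome. Compound 4 is therefore estimated at 55000 nM, in a range from 20000 nM to 130000 nM.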

Compound 4, concentration lethal to 50% of the cells: 37200 nM
For compound 4 the middle estimate is 1.5-fold (0.17 log units) above the measured one; low and high end bracket the measured number.
By their numbers in this assay, from the lowest: compounds 4, 2 and 1 (each within the scatter of the next, the first and the last beyond it).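

Putting methoxy in place of hydrogen on this aromatic carbon, ortho to a methoxy group, gives a 1.6-fold lower number from compound 2 to compound 4 (0.20 log units; within the scatter) in this assay, so the two compounds cannot be placed in any order. The earlier measured step exchanged one pair of substituents for another, whereas this one shows that a ring carbon carrying only hydrogen in compound 2 can take an added methoxy group while the read-out stays within the scatter. The data shown offer no measurement that could explain why this added group leaves the number so close to that of compound 2.

From the compounds shown here alone, whether a hydroxyl group, an amine or a carboxylic acid on this same ring carbon would give a step beyond the scatter remains open, and so does the outcome for a longer chain such as ethoxy. It also remains open whether the position stays this undemanding when the hydrogen is replaced by a group unlike methoxy, such as fluorine, since methoxy is the only group shown entering at this carbon.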